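The source may hold more compounds than are shown below. What is called first, only, known or untested is meant among the compounds shown, and "the series" means these compounds.

Compound 1 `N#Cc1ccnc(Oc2nn(C3CCC3)c3ncnc(N)c23)c1` is measured in an ADME assay on microsomes from liver (Mus musculus) for metabolic stability, read by LC-MS, using NADPH, with a stated time of 10 min, tested at 10 uM (on this read-out higher numbers stand for a longer-lived compound and lower numbers for a shorter-lived compound), where compound 1 gives 0.4 h. Among the numbers shown, compound 1 holds the highest of two. Compound 3 `Nc1ncnc2c1c(Oc1cccc(Cl)c1)nn2[C@H]1C[C@H](F)C1` in this assay gives 0.065 h, a lower number than compound 1. Compound 2 `N#Cc1ccnc(Oc2nn([C@H]3C[C@H](O)C3)c3ncnc(N)c23)c1` in this assay reaches only a limit, > 2.41 h, not a number; this limit is the one at which one of the three values sits (the limit of > 2.41 h in this assay, at which 1 of the 3 values shown sits). Going by the values given here, the single one-place step among the measured compounds is the change an at least 6.0-fold higher number from compound 1 to compound 2 (0.77 log units; beyond the scatter), a hydroxy in place of hydrogen on a saturated ring carbon.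

Compound 4 `Nc1ncnc2c1c(Oc1cc(C(F)(F)F)ccn1)nn2C1CCC1` has not yet been measured in this assay. It differs from compound 1 in one place (trifluoromethyl in place of cyano on an aromatic carbon). No measured step touches that position or that pair of groups: the only step shown concerns the saturated ring, not the six-membered aromatic ring, so it gives no direct guide. With nothing pointing either way, the expectation for compound 4 is a step of about no change at the digits printed from compound 1 to compound 4 (within the scatter), that is, no change beyond the scatter. The estimate for compound 4 in this assay is therefore 0.4 h, expected to fall between 0.15 h and 1.2 h.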

Compound 4, half-life: 0.128 h
Compound 4: the middle estimate sits 3.1-fold (0.49 log units) above what was measured, and the stated range ends above it.
By their numbers in this assay, from the lowest: compounds 3 and 4 (each within the scatter of the next); then compound 1. At a limit, above all of these: compound 2.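

In this assay, trifluoromethyl in place of cyano on this aromatic carbon, opposite the ring nitrogen, gives a 3.1-fold lower number from compound 1 to compound 4 (0.49 log units; beyond the scatter) and so shows that this position of the six-membered aromatic ring has a bearing on the half-life. The earlier one-place step concerned only the saturated ring and ran upward, whereas this first one-place change on the aromatic ring runs downward, at a modest size, with the larger group of the two entering and the triple bond and the hydrogen-bond acceptor of the cyano group leaving. Nothing among the compounds shown bears on why the number falls with this change.

On these data alone, with one replacement at this position, it remains open whether a smaller group such as methyl, or an amide or a methoxy group, would keep the half-life of compound 1 or shorten it as trifluoromethyl does. As far as these compounds go, it also remains open whether the hydroxy on the saturated ring, which raised the number for compound 2, would do the same with trifluoromethyl in place.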